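The source may report more compounds than this note shows. Statements on the series, on what has been measured and on what is new or still open speak of the compounds shown alone.

Working notes on the series. For the measured compounds named here, in a functional assay on HepG2 cells (Homo sapiens) for antiproliferative activity, read by CCK-8 assay, with a stated time of 72 h (a lower number here means a stronger inhibitor, a higher number a weaker inhibitor), compound 1 (`Nc1ccccc1NC(=O)c1ccc(Cn2cnc3c(Nc4ccccc4)nc(Cl)nc32)cc1`) gives 4180 nM and compound 2 (`CCCCn1cnc2c(Nc3ccccc3)nc(NCOCc3ccc(C(=O)Nc4ccccc4N)cc3)nc21`) gives 4090 nM as the only other measured number. These two values lie within the usual scatter of each other, so compound 1 stands on a par with compound 2. Compound 3 (`Nc1ccccc1NC(=O)c1ccc(Cn2cnc3c(Nc4cccc(Cl)c4)nc(Cl)nc32)cc1`) keeps the core of compound 1 and turns its phenyl into 3-chlorophenyl (chloro in place of hydrogen on an aromatic carbon) with chloro in place of hydrogen on an aromatic carbon, meta to a large group. Going by the values given here, no measured step bears on this change, so the expectation is loose. A modest move towards a lower number is expected in this assay and it may not clear the scatter. The estimated move is a 1.7-fold lower number from compound 1 to compound 3 (0.22 log units; within the scatter) on this reasoning. Compound 3 is estimated at 2500 nM within a range of 800 nM to 6500 nM in this assay for now.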

Compound 3, half-maximal inhibitory concentration: 9800 nM
Compound 3: middle estimate off by 3.9-fold (0.59 log units), on the low side; measured number outside the range, above it.
By their numbers in this assay, from the lowest: compounds 2 and 1 (each within the scatter of the next); then compound 3.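

In this assay, for the compounds shown here, chloro in place of hydrogen on an aromatic carbon, meta to a large group, gives a 2.3-fold higher number from compound 1 to compound 3 (0.37 log units; beyond the scatter), the only step so far and one that clears the scatter. This position therefore does not take the added chlorine without a modest cost in this assay, at least for the pair phenyl to 3-chlorophenyl on the core of compound 1. No measurement shown here explains this rise in the number.

Going by these compounds, whether the cost belongs to chloro alone or to any group at this place stays open, and fluoro, methyl, methoxy or an amine on the same ring would separate these readings. Also open, on these data alone, is whether the same change carries over to compound 2, whose other parts differ from those of compound 1.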